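A Bromine on the Shared Core: Compound 3 Expected Near Compound 2

A few compounds are considered here, and "the series" means these few. Any claim that something is new, unique, unknown or untested is made for them only; others in the source may bear on it.

Compound 2 `COc1ccc2[nH]cc(-c3cnc(N(C)[C@@H]4C[C@H]5O[C@@](C)([C@@H]4OC)n4c6ccccc6c6c7c(c8c9ccccc9n5c8c64)C(=O)NC7)s3)c2c1` has the lowest number of the two measured compounds in a functional assay on MV4-11 cells (Homo sapiens) for antiproliferative activity, read by CellTiter-Glo, with a stated time of 72 h (on this read-out lower numbers stand for stronger inhibition and higher numbers for weaker inhibition), where compound 2 gives 360 nM. Its nearest neighbour is compound 1 `CO[C@@H]1[C@H](N(C)c2ncc(-c3c[nH]c4ccc(F)cc34)s2)C[C@H]2O[C@]1(C)n1c3ccccc3c3c4c(c5c6ccccc6n2c5c31)C(=O)NC4`, which in this assay gives 510 nM; the step of a 1.4-fold lower number from compound 1 to compound 2 (0.15 log units; within the scatter) concerns a methoxy in place of fluoro on an aromatic carbon. Compound 3 `COc1ccc2[nH]cc(-c3cnc(N(C)[C@@H]4C[C@H]5O[C@@](C)([C@@H]4OC)n4c6ccccc6c6c7c(c8c9cc(Br)ccc9n5c8c64)C(=O)NC7)s3)c2c1` is compound 2 with one further change: bromo in place of hydrogen on an aromatic carbon, on an aromatic carbon of a six-membered aromatic ring of carbon only, part of a fused or bridged system of eight rings, meta to a fused ring and para to a fused ring. Within the data shown here, no measured step touches this part of the shared core; the single known step lies elsewhere and was within the scatter. The number for compound 3 is therefore expected to stay close to that of compound 2, with an estimated step of a 1.1-fold higher number from compound 2 to compound 3 (0.05 log units; within the scatter) not beyond the scatter. Compound 3 is estimated at 400 nM, within a range of 130 nM to 1200 nM.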

Compound 3, half-maximal inhibitory concentration: 510 nM
For compound 3 the middle estimate is 1.3-fold (0.11 log units) below the measured one; the range from low to high includes it.
By their numbers in this assay, from the lowest: compounds 2, 1 and 3 (each within the scatter of the next).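

Compound 3 is the only compound shown with a change on this part of the shared core, and in this assay bromo in place of hydrogen gives a 1.4-fold higher number from compound 2 to compound 3 (0.15 log units; within the scatter) with the methoxy group of compound 2 kept in place. This aromatic carbon, meta to a fused ring and para to a fused ring, therefore takes a bromine, one added heavy atom, without a shift beyond the scatter in this cell read-out. No measurement shown here bears on the reason for this result.

The compounds shown leave open whether this tolerance extends to other groups at the same carbon, such as an amine, a carboxylic acid or a longer chain. They also leave open how bromo would read on the other aromatic carbons of this ring.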